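Naphthalen-2-yl tried on the ring nitrogen of compound 3

The source may report more compounds than this note shows. Statements on the series, on what has been measured and on what is new or still open speak of the compounds shown alone.

Measured so far in a functional assay on K562 cells (Homo sapiens) for antiproliferative activity, read by MTT assay, with a stated time of 48 h; a higher number here means a weaker inhibitor, a lower number a stronger inhibitor:
Compound 1, `COc1ccc(-c2ccc3c(c2)C(=O)C(=O)N3C)cc1`, gives 4980 nM.
Compound 2, `CCN1C(=O)C(=O)c2cc(-c3ccc(OC)cc3)ccc21`, gives 2200 nM.
Compound 3, `COc1ccc(-c2ccc3c(c2)C(=O)C(=O)N3Cc2cc(C)cc(C)c2)cc1`, gives 140 nM.

Compound 3 holds the lowest number of the three. The nearest is compound 2, and the step of a 16-fold lower number from compound 2 to compound 3 (1.20 log units; beyond the scatter) is large; the furthest is compound 1, and the step of a 36-fold lower number from compound 1 to compound 3 (1.55 log units; beyond the scatter) is larger still. The small step of a 2.3-fold lower number from compound 1 to compound 2 (0.35 log units; beyond the scatter) shows that adding a methyl on the chain carbon bound to the ring nitrogen moves the number only modestly, whereas the 3,5-dimethylphenyl at that place accounts for nearly all of the gain.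

Compound 4, `COc1ccc(-c2ccc3c(c2)C(=O)C(=O)N3Cc2ccc3ccccc3c2)cc1`, differs from compound 3 in one place: naphthalen-2-yl in place of 3,5-dimethylphenyl on a saturated chain carbon bound to an amide-type nitrogen in a ring. Within the data shown here, no measured step exchanges one aryl group for another at this carbon; the steps that bear on it only show that an aryl group here, rather than hydrogen or methyl, lowers the number strongly. Since compound 4 keeps an aryl group at the same place, the number in this assay is expected to stay close to that of compound 3, with the step of a 1.3-fold lower number from compound 3 to compound 4 (0.10 log units; within the scatter) estimated as small. Compound 4 is estimated at 110 nM, within a range of 35 nM to 350 nM.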

Compound 4, half-maximal inhibitory concentration: 400 nM
Compound 4: the middle estimate sits 3.6-fold (0.56 log units) below what was measured; the whole stated range lies below it.
By their numbers in this assay, from the lowest: compound 3; then compound 4; then compound 2; then compound 1.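

Among the compounds shown, the aryl group on the saturated chain carbon bound to the ring nitrogen is not interchangeable in this assay: replacing 3,5-dimethylphenyl with naphthalen-2-yl gives a modest but real loss (a 2.9-fold higher number from compound 3 to compound 4 (0.46 log units; beyond the scatter)). The benefit of an aryl group at this place does survive the exchange, as naphthalen-2-yl still improves on methyl (a 5.5-fold lower number from compound 2 to compound 4 (0.74 log units; beyond the scatter)) and on hydrogen (a 12-fold lower number from compound 1 to compound 4 (1.10 log units; beyond the scatter)), yet both gains are smaller than those obtained with 3,5-dimethylphenyl (a 16-fold lower number from compound 2 to compound 3 (1.20 log units; beyond the scatter); a 36-fold lower number from compound 1 to compound 3 (1.55 log units; beyond the scatter)). The entering group is the larger by count, with 10 heavy atoms and 2 aromatic rings against 8 and one, so more aromatic carbon at this place did not by itself lower the number in this pair.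

No measurement offered here accounts for the order of these two aryl groups.

As far as these compounds go, it remains open how unsubstituted phenyl, a pyridine ring or a longer chain carrying the aryl group would compare with compound 3 at this place.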